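This account rests on a few compounds, and the source may have more. Where it says the series, first, only, none or still open, it means among the compounds named here.

Measured compounds:
- Compound 1, `COc1cc(N(C)C(=O)c2cccc([N+](=O)[O-])c2)cc(OC)c1OC`: in a functional assay on ONS-76 cells (Homo sapiens) for cytotoxicity, read by MTT assay, with a stated time of 72 h (a higher number here means a weaker inhibitor, a lower number a stronger inhibitor), compound 1 gives >= 125000 nM, which is a limit of the assay and not a number.
- Compound 2, `COc1cc(N(C)C(=O)N(C)c2cccc([N+](=O)[O-])c2)cc(OC)c1OC`: compound 2 gives >= 125000 nM, again a limit.
- Compound 3, `COc1cc(N(C)C(=O)N(C)c2cccc(F)c2)cc(OC)c1OC`: compound 3 gives >= 125000 nM, also a limit.

How the core of compound 1 differs from that of compound 2 is not broken down here. Compound 3 arises from compound 2 by fluoro in place of nitro on an aromatic carbon. The step this made, a step that the two limits leave unreadable from compound 2 to compound 3, stays unreadable because of the limit of >= 125000 nM in this assay, at which 3 of the 3 values shown sit.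

Compound 4, `COc1cc(N(C)C(=O)c2cccc(F)c2)cc(OC)c1OC`, is not yet measured. It arises from compound 1 by fluoro in place of nitro on an aromatic carbon, the same change at the same place. Only limits are known for compound 1 and for the pair that carries this change, so no direction can be read for it.

The step expected from compound 1 to compound 4 in this assay is a number no higher from compound 1 to compound 4 (the limit leaves the size open), resting on the unreadable step between compound 2 and compound 3 and on the limit of compound 1. Compound 4 is accordingly expected to sit at 125000 nM, estimated between 50000 nM and 300000 nM, most likely reported as a limit again.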

Compound 4, half-maximal inhibitory concentration: >= 125000 nM
Compound 4 gave a limit, no number; the forecaster's own chance of this, stated with the estimate: 85%; the middle value lies on the limit itself.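

No new step can be read between compound 1 and compound 4 in this assay, since both give only a limit of the assay and not a number: the limit of >= 125000 nM in this assay, at which 4 of the 4 values shown sit. The compounds shown leave open how fluoro and nitro compare on the shared core, and which structural change, if any, would yield a number in this assay.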